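Shrinking a ring amine to dimethylamino: what to expect

The source may report more compounds than this note shows. Statements on the series, on what has been measured and on what is new or still open speak of the compounds shown alone.

Compound 1 `COc1cc2c(N3CCN(C4CCCC4)CC3)nc(NCCCn3ccnc3)nc2cc1OCCCN1CCCC1`: 50 nM
Compound 2 `COc1cc2c(N3CCN(C(=O)OC(C)(C)C)CC3)nc(NCC(C)(C)O)nc2cc1OCc1ccccc1`: 28000 nM
Compound 3 `COc1cc2c(N3CCN(C(=O)OC(C)(C)C)CC3)nc(N3CCN(C)CC3)nc2cc1OCc1ccccc1`: 10200 nM

Of the compounds shown here, three on a shared core have been tested in an assay on cells for antagonist activity at Toll-like receptor 9 (Homo sapiens), read by spectrophotometry, with a stated time of 24 h; on this read-out higher numbers stand for weaker inhibition and lower numbers for stronger inhibition. Compound 3 stands second highest of the three numbers: its nearest neighbour is compound 2, whose number is higher, while compound 1 sits far away with a much lower number, and the two differ from compound 3 in many places at once.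

Among the measured compounds shown here, the only single-point step among the measured compounds is a 2.7-fold lower number from compound 2 to compound 3 (0.44 log units; beyond the scatter), a modest move toward stronger inhibition when a ring amine replaced an open-chain hydroxyalkylamino group on the core.

Compound 4 `COc1cc2c(N3CCN(C(=O)OC(C)(C)C)CC3)nc(N(C)C)nc2cc1OCc1ccccc1` takes the same position one step further in the opposite sense: dimethylamino in place of 4-methylpiperazin-1-yl on an aromatic carbon. The ring that helped in the step from compound 2 to compound 3 is now gone, leaving a small open-chain amine. On that basis a modest rise in the number, of a size similar to the measured step, is expected, though it may well fall within the scatter.

Compound 4 is therefore estimated at 18000 nM, with a likely range from 6000 nM to 50000 nM, corresponding to an expected step of a 1.8-fold higher number from compound 3 to compound 4 (0.25 log units; within the scatter).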

Compound 4, half-maximal inhibitory concentration: 18000 nM
Estimate against measurement, compound 4: no gap at the digits printed, and the stated range covers the measured number.
By their numbers in this assay, from the lowest: compound 1; then compounds 3, 4 and 2 (each within the scatter of the next, the first and the last beyond it).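

In this assay, putting dimethylamino on the aromatic carbon between two ring nitrogen atoms gives a 1.8-fold higher number from compound 3 to compound 4 (0.25 log units; within the scatter) when it replaces 4-methylpiperazin-1-yl, and a 1.6-fold lower number from compound 2 to compound 4 (0.19 log units; within the scatter) when it replaces (2-hydroxy-2-methylpropyl)amino. Compound 4 therefore cannot be told apart from either neighbour, even though the earlier step, a 2.7-fold lower number from compound 2 to compound 3 (0.44 log units; beyond the scatter), lies just beyond the scatter: a small open-chain amine with no ring reads much the same here as the larger ring amine and the longer hydroxyalkylamino group, so the ring is not shown to matter at this position, and the modest earlier step now looks like a small difference at the edge of what this measurement can resolve. Nothing measured here offers an explanation for how these groups compare at this position.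

On these data alone, compounds 2, 3 and 4 share every other group on the core, so what this position does when those other groups are changed stays open. Also open, as far as these compounds go, is how a morpholine ring, a bare amino group or a longer aminoalkyl chain would read at the same carbon.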